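Bromo for chloro on a guanidine-to-amidine pair

The source may report more compounds than this note shows. Statements on the series, on what has been measured and on what is new or still open speak of the compounds shown alone.

Measured so far:
compound 1, `N=C(N)Nc1cccc(C(=O)NNC(=O)CC(CC(=O)O)c2ccc(Cl)cc2)c1`, 1.68
compound 2, `N=C(N)Nc1cccc(C(=O)NNC(=O)CC(CC(=O)O)c2ccc(Br)cc2)c1`, 1.95
compound 3, `CC(=N)Nc1cccc(C(=O)NNC(=O)CC(CC(=O)O)c2ccc(Cl)cc2)c1`, 2

Three compounds of this series have been characterised in a physicochemical assay for lipophilicity; on this read-out higher numbers stand for higher lipophilicity and lower numbers for lower lipophilicity. Compound 1 and compound 2 share a core and differ only in bromo in place of chloro on an aromatic carbon; in this assay the step from one to the other reads a number 0.27 log units higher from compound 1 to compound 2 (within the scatter). Compound 1 and compound 3 differ in their cores, and that difference is methyl in place of amino on a carbon with a double bond to nitrogen; the step in this assay is a number 0.32 log units higher from compound 1 to compound 3 (beyond the scatter). The values of compound 2 and compound 3 lie within the usual scatter of each other, so no order between them is claimed.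

Compound 4, `CC(=N)Nc1cccc(C(=O)NNC(=O)CC(CC(=O)O)c2ccc(Br)cc2)c1`, has not yet been measured in this assay. It carries the core of compound 3 and differs from compound 3 in bromo in place of chloro on an aromatic carbon. This is the same change that separates compound 1 from compound 2, made at the same place, and among the four compounds it occurs twice. From compound 3 to compound 4 the step is expected to be a number 0.27 log units higher from compound 3 to compound 4 (within the scatter), beside the earlier step, because the change from compound 1 to compound 2 gave a number 0.27 log units higher from compound 1 to compound 2 (within the scatter) and nothing among the three measured compounds suggests the second core should respond differently. For compound 4 the estimate in this assay is therefore 2.27, expected to fall between 2 and 2.55.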

Compound 4, partition coefficient: 2.27
Compound 4: the middle estimate sits on the measured number at the digits printed; low and high end bracket the measured number.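

In this assay the change of bromo for chloro on the core of compound 3 reads a number 0.27 log units higher from compound 3 to compound 4 (within the scatter), the same as a number 0.27 log units higher from compound 1 to compound 2 (within the scatter) on the core of compound 1, and the change of methyl for amino reads a number 0.32 log units higher from compound 2 to compound 4 (beyond the scatter), the same as a number 0.32 log units higher from compound 1 to compound 3 (beyond the scatter), so at the digits printed the two changes add up cleanly across all four compounds. This shows that the bromo for chloro step carried from one core to the other without any departure, but both of its readings lie within the scatter, so neither one alone establishes a real difference between the bromo and chloro compounds, and two cores do not show how the change would behave on any third core. The data shown offer no measurement that bears on why the steps agree.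

The compounds shown leave open whether fluoro, iodo or methoxy at the same place on the aromatic ring would also carry unchanged from one core to the other. They also leave open whether the agreement would hold with an ethyl group in place of the methyl, or with a methyl ester in place of the carboxylic acid.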